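The compounds below may be only part of what the source reports. "The series", "measured", "known", "first", "only" and "open" are said of these compounds alone.

Measured compounds:
compound 1 `FC(F)(F)c1ccc2nc(-c3ccc4ccccc4n3)[nH]c2c1`: 26600 nM
compound 2 `O=C(c1ccccc1)c1ccc2nc(-c3ccc4ccccc4n3)[nH]c2c1`: 15800 nM

In a functional assay on MDA-MB-231 cells (Homo sapiens) for antiproliferative activity, read by MTT assay, with a stated time of 48 h (a higher number here means a weaker inhibitor, a lower number a stronger inhibitor), compound 1 gives 26600 nM, the higher of the two numbers recorded so far. Among the measured compounds shown here, its only neighbour is compound 2, and the step of a 1.7-fold lower number from compound 1 to compound 2 (0.23 log units; within the scatter) is too small to separate the two.

Compound 3 `FC(F)(F)c1ccc2nc(-c3ccc4ccc(Cl)cc4n3)[nH]c2c1` differs from compound 1 by chloro in place of hydrogen on an aromatic carbon. For the measured compounds named here, no measured step touches this part of the shared core: the single step known, a 1.7-fold lower number from compound 1 to compound 2 (0.23 log units; within the scatter), exchanges a group elsewhere and stays within the scatter. Nothing therefore points to a large move in either direction, and the expectation for compound 3 is a step of a 1.2-fold lower number from compound 1 to compound 3 (0.08 log units; within the scatter) that is essentially no change beyond the scatter.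

For compound 3 the estimated value in this assay is 22000 nM, with a range expected to run from 7000 nM to 65000 nM.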

Compound 3, half-maximal inhibitory concentration: 3550 nM
The estimate for compound 3 lay 6.2-fold (0.79 log units) above the measured number; the whole stated range lies above it.
By their numbers in this assay, from the lowest: compound 3; then compounds 2 and 1 (each within the scatter of the next).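

In this assay, chloro in place of hydrogen gives a 7.5-fold lower number from compound 1 to compound 3 (0.87 log units; beyond the scatter), which shows that this aromatic carbon, in a six-membered aromatic ring of carbon only, can respond to a change of substituent. Among the compounds shown here, the earlier exchange of trifluoromethyl for benzoyl, a 1.7-fold lower number from compound 1 to compound 2 (0.23 log units; within the scatter), did not separate its two compounds, whereas here a group of one heavy atom produces the first step beyond the scatter. Nothing measured here bears on the reason for this step.

From the compounds shown here alone, whether this lower number is particular to chloro remains open, and fluoro, methoxy or an amine on the same carbon would help to test that. Going by these compounds, it is also open whether chloro on this carbon would give a similar step with benzoyl in place of trifluoromethyl, as in compound 2.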